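The source may report more compounds than this note shows. Statements on the series, on what has been measured and on what is new or still open speak of the compounds shown alone.

Measured so far:
compound 1, `COc1ccc(S(=O)(=O)c2cnc3ccc(C)cc3c2N2CCC(C)CC2)cc1Cl` — 93%
compound 2, `Cc1ccc(S(=O)(=O)c2cnc3ccc(Cl)cc3c2N2CCC(C)CC2)cc1C` — 84%
compound 3, `COc1ccc(S(=O)(=O)c2cnc3c(F)cccc3c2N2CCC(C)CC2)cc1` — 67%

All three values come from an assay on isolated protein for displacement of a labelled ligand from metabotropic glutamate receptor 5 (Homo sapiens), with a stated time of 60 min, tested at 1 uM; a higher number here means more inhibition at the concentration tested (going by the name of the read-out), a lower number less inhibition. On these numbers compound 3 stands lowest of the three. Its nearest neighbour is compound 2, which lies higher by a margin beyond the usual scatter; compound 1 lies higher still, again beyond the scatter. For the measured compounds named here, none of the three pairs differs in one place only, so no single step between measured compounds can be read off; the three values show only that the two compounds carrying a substituted core and a differently substituted phenyl on the sulfonyl sulfur return the higher inhibition.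

Compound 4, `Cc1ccc(S(=O)(=O)c2cnc3c(F)cccc3c2N2CCC(C)CC2)cc1F`, is not yet measured. It differs from compound 3 in one place: 3-fluoro-4-methylphenyl in place of 4-methoxyphenyl on a sulfonyl sulfur. Going by the values given here, no measured pair isolates this change. Compound 2, whose phenyl on the sulfonyl sulfur carries two methyl groups rather than a methoxy, gives 84%, but it also differs in the core, so that number cannot be carried over directly.

The expected step from compound 3 to compound 4 in this assay is a number 5 percentage points higher from compound 3 to compound 4 (within the scatter), a small rise at most, likely within the scatter. Compound 4 is estimated at 72%, with a range from 48% to 90%.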

Compound 4, a percentage reported as inhibition, at one concentration (the size of the read-out at that concentration, not a potency): 93%
Estimate against measurement, compound 4: 21 percentage points below, and the stated range ends below it.
By their numbers in this assay, from the lowest: compound 3; then compounds 2, 1 and 4 (each within the scatter of the next).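

In this assay, changing only the group on a sulfonyl sulfur, with the core and the 4-methylpiperidine-bearing remainder of the structure held constant, gives a number 26 percentage points higher from compound 3 to compound 4 (beyond the scatter). For the compounds shown here, this is the first step that can be read at one place, and it shows that this position alone can move the read-out by more than the scatter, something the earlier compounds could not show, since they differ from one another in the core as well as in the aryl group. The exchange of 4-methoxyphenyl for 3-fluoro-4-methylphenyl keeps the heavy-atom count and the carbon-only aromatic ring, so the step marks a swap of substituents rather than a change in group size, and nothing measured here bears on what lies behind it.

One step cannot separate the loss of the methoxy group from the arrival of the fluorine or the methyl group, a question that 4-methylphenyl and 3-fluorophenyl on the same sulfonyl sulfur would address. Also open, as far as these compounds go, are whether the step carries over to the other cores and how it translates into potency, since the read-out comes from a single concentration.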